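A few compounds are considered here, and "the series" means these few. Any claim that something is new, unique, unknown or untested is made for them only; others in the source may bear on it.

Measured in an ADME assay (liver) for metabolic stability, with Liver microsome (Homo sapiens) as the target, using microsomes and NADPH, with a stated time of 30 min, tested at 1 uM; a higher number here means faster removal of the compound, a lower number slower removal:
- Compound 1 `Nc1ccc(S(=O)(=O)N2CCN(c3ncc(C(O)(C(F)(F)F)C(F)(F)F)cc3-c3ccc4scnc4c3)CC2)cn1`: 39 mL.min-1.g-1
- Compound 2 `Nc1ccc(S(=O)(=O)N2CCN(c3ncc(C(O)(C(F)(F)F)C(F)(F)F)cc3-c3cccc4[nH]ncc34)CC2)cn1`: 42 mL.min-1.g-1

Compound 2 stands within the usual scatter of compound 1, so neither sets itself apart in this assay. Compound 3 `Nc1ccc(S(=O)(=O)N2CCN(c3ncc(C(O)(C(F)(F)F)C(F)(F)F)cc3-c3cc4ccccc4s3)CC2)cn1` keeps the rest of compound 2 but puts 1-benzothiophen-2-yl in place of 1H-indazol-4-yl on an aromatic carbon. Going by the values given here, only one measured step touches this same place, a swap of 1,3-benzothiazol-5-yl for 1H-indazol-4-yl, and it was small: a 1.1-fold higher number from compound 1 to compound 2 (0.03 log units; within the scatter). On that single precedent, the expected step is no larger than the scatter: a 1.1-fold higher number from compound 2 to compound 3 (0.03 log units; within the scatter). The estimate for compound 3 is 45 mL.min-1.g-1, with an expected range of 22 mL.min-1.g-1 to 95 mL.min-1.g-1.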

Compound 3, intrinsic clearance in microsomes: < 14 mL.min-1.g-1
Compound 3: no number, only a limit (the forecaster's own chance of this, stated with the estimate: 3%); middle value at least 3.2-fold (0.50 log units) from the limit.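

In this assay, this aromatic carbon, two atoms from the ring nitrogen, turns out to be able to shift the read-out, which the earlier swap did not show: 1-benzothiophen-2-yl gives an at least 3.0-fold lower number from compound 2 to compound 3 (0.47 log units; beyond the scatter), and an at least 2.7-fold lower number from compound 1 to compound 3 (0.44 log units; beyond the scatter). Compound 3 has only a limit of the assay, not a number, so the full size of these steps is unknown: the limit of < 14 mL.min-1.g-1 in this assay, at which 1 of the 3 values shown sits.

Compound 3 has no ring nitrogen in this group and a different attachment point, and the compounds shown do not separate these two changes. 1-Benzothiophen-5-yl or 1H-indol-2-yl at this place would pull them apart.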